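The compounds below may be only part of what the source reports. "The series", "measured", "known", "first", "only" and "open" are said of these compounds alone.

The measured compounds:
Compound 1 `C=CC(=O)Nc1cccc(-n2c(-c3nc(-c4cnn(C5CCN(C)CC5)c4)cnc3N)nc3ccccc32)c1` — in a physicochemical assay for solubility, at pH 7.4 (on this read-out lower numbers stand for lower solubility and higher numbers for higher solubility), compound 1 gives < 10000 nM, a limit of the assay rather than a number.
Compound 2 `C=CC(=O)Nc1ccccc1Cn1c(-c2nc(-c3cnn(C4CCN(C)CC4)c3)cnc2N)nc2ccccc21` — in this assay compound 2 gives 35000 nM.

Compound 1 therefore stands only at a limit, as shown by the limit of < 10000 nM in this assay, at which 1 of the 2 values shown sits, and the single measured step, an at least 3.5-fold higher number from compound 1 to compound 2 (0.54 log units; beyond the scatter), runs from that limit to a number and concerns a change at the aromatic nitrogen, not the piperidine.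

Compound 3 `C=CC(=O)Nc1cccc(-n2c(-c3nc(-c4cnn(C5CCN(CC)CC5)c4)cnc3N)nc3ccccc32)c1` differs from compound 1 by methyl in place of hydrogen on a saturated chain carbon bound to an amine nitrogen in a ring. Among the compounds with values here, no measured step touches this position, so the change from compound 1 to compound 2 gives no direct guide; it only shows how far a step from the limit can reach. Compound 3 is expected to stay close to compound 1, with a step that the limit leaves unreadable from compound 1 to compound 3 that is not expected to go beyond the scatter. The solubility of compound 3 is estimated at 6000 nM, within a range from 1500 nM to 20000 nM.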

Compound 3, solubility: < 10000 nM
Compound 3: a limit, no number (the forecaster's own chance of this, stated with the estimate: 60%); the middle value lies beyond the limit too.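

Within the data shown here, compound 1 and compound 3 both stand at a limit in this assay, so no step between them can be read: the limit of < 10000 nM in this assay, at which 2 of the 3 values shown sit. The compounds shown leave open what the change from 1-methylpiperidin-4-yl to 1-ethylpiperidin-4-yl does to this read-out.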